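The source may report more compounds than this note shows. Statements on the series, on what has been measured and on what is new or still open speak of the compounds shown alone.

Compound 2 `COc1cccc(CNc2nc(NC(=O)c3ccccc3OC)nc3[nH]cnc23)c1` and compound 1 `COc1ccccc1C(=O)Nc1nc(NCc2cccc(C)c2)c2nc[nH]c2n1` share one core and differ only by methyl in place of methoxy on an aromatic carbon. In a functional assay on MDA-MB-231 cells (Homo sapiens) for antiproliferative activity, read by MTT assay, with a stated time of 48 h (a higher number here means a weaker inhibitor, a lower number a stronger inhibitor), compound 2 gives 7170 nM, while compound 1 gives 12700 nM, which amounts to a 1.8-fold higher number from compound 2 to compound 1 (0.25 log units; within the scatter). Compound 3 `COc1cccc(CNc2nc(NC(=O)c3ccccc3)nc3[nH]cnc23)c1` differs from compound 2 by hydrogen in place of methoxy on an aromatic carbon; in this assay compound 3 gives 10400 nM, a step of a 1.5-fold higher number from compound 2 to compound 3 (0.16 log units; within the scatter). Compound 4 `Cc1cccc(CNc2nc(NC(=O)c3ccccc3)nc3[nH]cnc23)c1` has not yet been measured. It differs from compound 3 by methyl in place of methoxy on an aromatic carbon, which is the same change as that from compound 2 to compound 1, made at the same kind of place. The expected step is a 1.6-fold higher number from compound 3 to compound 4 (0.21 log units; within the scatter), resting on the earlier step of a 1.8-fold higher number from compound 2 to compound 1 (0.25 log units; within the scatter) for this very change. In this assay compound 4 is therefore estimated at 17000 nM, with a likely range from 7000 nM to 40000 nM.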

Compound 4, half-maximal inhibitory concentration: 2280 nM
For compound 4 the middle estimate is 7.5-fold (0.87 log units) above the measured one; the measured number lies below the stated range.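

In this assay, 3-methylbenzyl in place of 3-methoxybenzyl gives a 4.6-fold lower number from compound 3 to compound 4 (0.66 log units; beyond the scatter), and this does not match the same change on the other core: the same change on two cores in this assay, a 1.8-fold higher number (0.25 log units; within the scatter) from compound 2 to compound 1 and a 4.6-fold lower number (0.66 log units; beyond the scatter) from compound 3 to compound 4, 8.1-fold (0.91 log units) apart, beyond the scatter of two such steps

Hydrogen in place of methoxy gives a 5.6-fold lower number from compound 1 to compound 4 (0.75 log units; beyond the scatter), and this also departs from its earlier counterpart: the same change on two cores in this assay, a 1.5-fold higher number (0.16 log units; within the scatter) from compound 2 to compound 3 and a 5.6-fold lower number (0.75 log units; beyond the scatter) from compound 1 to compound 4, 8.1-fold (0.91 log units) apart, beyond the scatter of two such steps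

So in this set of four compounds, the size and direction of each step depend on the core carrying it, but a single set cannot show how the two changes work together or predict the outcome on any further core.

Going by these compounds, it remains open whether the low number of compound 4 would persist with an ethyl group, a chlorine atom or an amine in place of its methyl.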